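Tolerance in MT4 Cells: Varying the Aryl Ether

This account rests on a few compounds, and the source may have more. Where it says the series, first, only, none or still open, it means among the compounds named here.

Compound 1 `N#Cc1ccc(Nc2nc(Oc3ccc(Cl)cc3Cl)c3ccccc3n2)cc1`: 32000 nM
Compound 2 `Cc1cccc(C)c1Oc1nc(Nc2ccc(C#N)cc2)nc2ccccc12`: 35000 nM
Compound 3 `COc1ccccc1Oc1nc(Nc2ccc(C#N)cc2)nc2ccccc12`: 150000 nM

Three compounds share one core and differ only in the group on the oxygen on the aromatic ring. In an ADME assay on MT4 cells (Homo sapiens) for cytotoxicity, read by MTT assay, with a stated time of 4 days (a higher number here means that more compound is tolerated, a lower number that less compound is tolerated), compound 1 gives 32000 nM, and compound 2 gives 35000 nM; the step of a 1.1-fold higher number from compound 1 to compound 2 (0.04 log units; within the scatter) is within the scatter. Compound 3 stands highest of the three, with 150000 nM in this assay, and both steps towards it are modest: a 4.7-fold higher number from compound 1 to compound 3 (0.67 log units; beyond the scatter) and a 4.3-fold higher number from compound 2 to compound 3 (0.63 log units; beyond the scatter).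

Compound 4 `Cc1cc(Br)cc(Br)c1Oc1nc(Nc2ccc(C#N)cc2)nc2ccccc12` has not yet been measured. It differs from compound 3 as follows: 2,4-dibromo-6-methylphenyl in place of 2-methoxyphenyl on an oxygen on an aromatic ring. The two steps that bear on this change are those from compound 1 and compound 2 to compound 3, where a halogenated or methylated ring gave a lower number than the 2-methoxyphenyl. Compound 4 carries both bromine and methyl on its ring, so a return towards the numbers of compound 1 and compound 2 is expected, a step of a 5.0-fold lower number from compound 3 to compound 4 (0.70 log units; beyond the scatter). Compound 4 is therefore estimated at 30000 nM, within a range from 12000 nM to 80000 nM.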

Compound 4, half-maximal cytotoxic concentration: 150000 nM
Beside the measured number, compound 4's estimate is 5.0-fold (0.70 log units) below it; measured number outside the range, above it.
By their numbers in this assay, from the lowest: compounds 1 and 2 (each within the scatter of the next); then compounds 3 and 4 (each within the scatter of the next).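

In this assay, among the compounds shown here, replacing 2-methoxyphenyl with 2,4-dibromo-6-methylphenyl gives no change at the digits printed from compound 3 to compound 4 (within the scatter), so the methoxy group is not the only group on this oxygen-linked ring that reaches this level. The new ring also stands apart from the other two, with a 4.3-fold higher number from compound 2 to compound 4 (0.63 log units; beyond the scatter) and a 4.7-fold higher number from compound 1 to compound 4 (0.67 log units; beyond the scatter), so halogen and methyl substituents do not by themselves go with the lower numbers: compounds 1 and 2 carry them and sit lower, while compound 4 carries both and does not. No supporting measurement is available to explain this result.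

The compounds shown leave open whether the number follows the bromine, the methyl group or their combination. They also leave open whether a ring bearing an amine or a carboxylic acid would sit with compounds 3 and 4 or with compounds 1 and 2.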